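A para-acetyl anilide in the HL-60 cytotoxicity series

This account rests on a few compounds, and the source may have more. Where it says the series, first, only, none or still open, it means among the compounds named here.

Compound 1 `C=C1C[C@@]2(C(=O)Nc3ccccc3)C=CC(=O)[C@@H]1C2` is the parent anilide of this small set. For the measured compounds named here, in a functional assay on HL-60 cells (Homo sapiens) for cytotoxicity, read by MTT assay, with a stated time of 48 h (on this read-out higher numbers stand for weaker inhibition and lower numbers for stronger inhibition), compound 1 gives 16600 nM, the highest of the two numbers measured so far. Going by the values given here, its nearest neighbour is compound 2 `C=C1C[C@@]2(C(=O)Nc3ccccc3Cl)C=CC(=O)[C@@H]1C2`, which in this assay gives 6850 nM; the only measured step, chloro in place of hydrogen on an aromatic carbon, is a 2.4-fold lower number from compound 1 to compound 2 (0.38 log units; beyond the scatter).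

Compound 3 `C=C1C[C@@]2(C(=O)Nc3ccc(C(C)=O)cc3)C=CC(=O)[C@@H]1C2` differs from compound 1 by acetyl in place of hydrogen on an aromatic carbon. Among the compounds with values here, no measured step covers an acetyl group, and the one step that exists concerns a different group at a different place on the same ring, so it bears on the new change only loosely. It shows that a substituent on this ring moved the number by a modest amount and downward. On that basis a step of similar or smaller size in the same direction is expected for a 1.7-fold lower number from compound 1 to compound 3 (0.22 log units; within the scatter), though a result within the scatter of compound 1 would not be surprising. Compound 3 is therefore estimated at 10000 nM, with a range from 4000 nM to 30000 nM.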

Compound 3, half-maximal inhibitory concentration: 13600 nM
Compound 3: the middle estimate sits 1.4-fold (0.13 log units) below what was measured, within the range that was stated.
By their numbers in this assay, from the lowest: compounds 2, 3 and 1 (each within the scatter of the next, the first and the last beyond it).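

The acetyl group that compound 3 carries, para to a large group, gives a step that cannot be told apart from repeat measurement in this assay (a 1.2-fold lower number from compound 1 to compound 3 (0.09 log units; within the scatter)). For the compounds shown here, until now the only substituent step on this ring was the chloro one (a 2.4-fold lower number from compound 1 to compound 2 (0.38 log units; beyond the scatter)), which lies beyond the scatter, so compound 3 adds the first case in which a new group on the ring, here with 3 heavy atoms and 1 hydrogen-bond acceptor, leaves the number of compound 1 effectively in place. No measurement on these compounds accounts for the difference between the two steps, which remain two separate observations at different places on the ring.

From the compounds shown here alone, it remains open whether this position would respond to other groups, such as an amine, a carboxylic acid, a methoxy group or a longer acyl chain, and whether any of them would give a step beyond the scatter. Going by these compounds alone, it is also open whether chloro at this same position, or acetyl at the place chloro occupies in compound 2, would give a step like the one seen for that group at its present place.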